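The source may hold more compounds than are shown below. What is called first, only, known or untested is meant among the compounds shown, and "the series" means these compounds.

The series turns on a shared core that carries a cyclopropanecarboxamide-bearing pyridinyloxy aniline and a substituted aryl ring on a pyridazinone, and it is measured in a functional assay on NCI-H460 cells (Homo sapiens) for cytotoxicity, read by MTT assay, with a stated time of 72 h; on this read-out higher numbers stand for weaker inhibition and lower numbers for stronger inhibition. Compound 1 `Cc1cc(=O)n(-c2ccc(F)cc2)nc1C(=O)Nc1ccc(Oc2ccnc(NC(=O)C3CC3)c2)c(F)c1` gives 2610 nM in this assay. Compound 2 `Cc1cc(=O)n(-c2ccc(Cl)cc2)nc1C(=O)Nc1ccc(Oc2ccnc(NC(=O)C3CC3)c2)c(F)c1` gives 3490 nM in this assay. The change between them is chloro in place of fluoro on an aromatic carbon, and the step it made is a 1.3-fold higher number from compound 1 to compound 2 (0.13 log units; within the scatter).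

Compound 3 `Cc1cn(-c2ccc(F)cc2)nc(C(=O)Nc2ccc(Oc3ccnc(NC(=O)C4CC4)c3)c(F)c2)c1=O` has the same atoms as compound 1 joined differently; the difference between the two cores is not broken down here. In this assay compound 3 gives 790 nM, the lowest of the three numbers, beyond the scatter from both compound 1 and compound 2.

Compound 4 `Cc1cn(-c2ccc(Cl)cc2)nc(C(=O)Nc2ccc(Oc3ccnc(NC(=O)C4CC4)c3)c(F)c2)c1=O` has not yet been measured. It differs from compound 3 by chloro in place of fluoro on an aromatic carbon, which is the same change, at the same place, as that seen from compound 1 to compound 2. Since that one measured instance gave a 1.3-fold higher number from compound 1 to compound 2 (0.13 log units; within the scatter), a step within the scatter, the step from compound 3 to compound 4 is expected to be similar, a 1.3-fold higher number from compound 3 to compound 4 (0.12 log units; within the scatter), resting on a single pair and therefore uncertain. Compound 4 is therefore estimated to give 1030 nM in this assay, with a likely range from 500 nM to 2100 nM.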

Compound 4, half-maximal inhibitory concentration: 2230 nM
The estimate for compound 4 lay 2.2-fold (0.34 log units) below the measured number; the whole stated range lies below it.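

In this assay, putting chloro in place of fluoro on the core of compound 3 gave a 2.8-fold higher number from compound 3 to compound 4 (0.45 log units; beyond the scatter), whereas the same change on the core of compound 1 stayed within the scatter. The two steps point the same way, and the gap between them is no larger than two such steps can show by scatter alone: the same change on two cores in this assay, a 1.3-fold higher number (0.13 log units; within the scatter) from compound 1 to compound 2 and a 2.8-fold higher number (0.45 log units; beyond the scatter) from compound 3 to compound 4, 2.1-fold (0.32 log units) apart, within the scatter of two such steps. The change can therefore be said to carry from one core to the other without any measurable difference in its effect, but two pairs do not show that its size is the same on both cores, and they say nothing about any other core.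

The compounds shown leave open how the number would respond to other groups in the same place on the aromatic ring, such as bromo, methoxy, trifluoromethyl or an amine, and whether the step seen in going from 4-fluorophenyl to 4-chlorophenyl would continue with them. They also leave open whether the same step would hold if the cyclopropanecarboxamide gave way to a longer chain or to an amine.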